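A few compounds are considered here, and "the series" means these few. Any claim that something is new, unique, unknown or untested is made for them only; others in the source may bear on it.

Measured compounds:

Compound 1, `CC1=C(N2CC2)C(=O)C(Cc2ccccc2)=C(N2CC2)C1=O`: 4.74
Compound 2, `CCOC(COC(N)=O)C1=C(N2CC2)C(=O)C(C)=C(N2CC2)C1=O`: 5.53

Of the compounds shown here, two sharing the same core have been measured in a functional assay on L1210 cells (Mus musculus), with a stated time of 1 days; on this read-out lower numbers stand for lower potency and higher numbers for higher potency (the scale is a negative logarithm). In this read-out compound 1 gives 4.74, the lower of the two numbers, and compound 2 gives 5.53, which is higher by an amount beyond the usual scatter. Compound 2 differs from compound 1 at more than one place, so those two numbers set a rough span for the series rather than tell what any single change does.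

Compound 3, `CC1=C(N2CC2)C(=O)C(CCCc2ccccc2)=C(N2CC2)C1=O`, differs from compound 1 at a single place: phenethyl in place of phenyl on a saturated chain carbon bound to a double-bonded ring carbon. For the measured compounds named here, no measured pair shows a change of this kind, so no step can be read off. With only the phenyl group replaced by a phenethyl group on the same saturated chain carbon, a small step is expected, likely within the scatter or slightly upward rather than a shift of the size seen between compound 1 and compound 2.

Compound 3 is therefore expected to give about 4.9, with a range from 4.3 to 5.5.

Compared with compound 1, this estimate means an expected step of a number 0.16 log units higher from compound 1 to compound 3 (within the scatter).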

Compound 3, logarithm of the reciprocal of the active concentration, log(1/C): 3.93
Beside the measured number, compound 3's estimate is 0.97 log units above it, and the stated range ends above it.
By their numbers in this assay, from the lowest: compound 3; then compound 1; then compound 2.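

In this assay, this position proves sensitive to what it carries: phenethyl in place of phenyl on a saturated chain carbon bound to a double-bonded ring carbon gives a step of a number 0.81 log units lower from compound 1 to compound 3 (beyond the scatter) and so costs potency. Both groups hold one six-membered aromatic ring of carbon only, with no hydrogen-bond donors or acceptors and no net charge, and the count of heavy atoms goes from 6 to 8, so this pair links the loss to a longer carbon link to the same ring rather than to a change in the kind of ring. Nothing at hand shows why the longer group goes with the lower number.

This single pair gives one direction for one change, so it cannot say whether potency would keep falling with a still longer chain or whether the fall is specific to phenethyl. It also leaves open how the position would respond to a group of another kind in place of phenyl, such as an amine or a carboxylic acid, or to a plain methyl group.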